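The compounds below may be only part of what the source reports. "The series", "measured", "known", "first", "only" and "open" are said of these compounds alone.

Of the compounds shown here, two measured so far share one core and differ in the group attached to the aryl amine. Compound 1 `O=C(Nc1cccc(-n2cc(-c3ccncc3)c(-c3ccc(Cl)c(O)c3)n2)c1)Nc1ccc(Cl)c(Cl)c1` carries that group through a urea; in a functional assay on 786-0 cells (Homo sapiens) for inhibition, read by sulforhodamine B assay, with a stated time of 48 h (a lower number here means a stronger inhibitor of growth, a higher number a weaker inhibitor of growth), compound 1 gives 7220 nM. Compound 2 `COc1cc(-c2nn(-c3cccc(NC(=O)c4ccc(Cl)c(C(F)(F)F)c4)c3)cc2-c2ccncc2)ccc1Cl` carries an amide whose ring bears a chloro and a trifluoromethyl group; in this assay compound 2 gives 11000 nM, the higher of the two numbers, although its gap to compound 1 lies within the scatter, so the two cannot be told apart. Compound 3 `COc1cc(-c2nn(-c3cccc(NC(=O)c4cccc(C(F)(F)F)c4)c3)cc2-c2ccncc2)ccc1Cl` follows from compound 2 by one change, (hydrogen in place of chloro on an aromatic carbon), so that 4-chloro-3-(trifluoromethyl)phenyl becomes 3-(trifluoromethyl)phenyl. Among the compounds with values here, no measured pair shows this change, so its effect rests on judgment alone. The step of a 1.3-fold higher number from compound 2 to compound 3 (0.10 log units; within the scatter) is expected to be small, if anything toward a slightly higher number, and within the scatter. Compound 3 is therefore estimated at 14000 nM, with a range from 5000 nM to 40000 nM.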

Compound 3, concentration for 50% growth inhibition: 2450 nM
The estimate for compound 3 lay 5.7-fold (0.76 log units) above the measured number; measured number below the stated range.
By their numbers in this assay, from the lowest: compound 3; then compounds 1 and 2 (each within the scatter of the next).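

In this assay the swap of hydrogen for chloro on the 4-chloro-3-(trifluoromethyl)phenyl ring gives a clear step (a 4.5-fold lower number from compound 2 to compound 3 (0.65 log units; beyond the scatter)), so this one position, ortho to a trifluoromethyl group, does affect growth inhibition, and here the form without chloro is the stronger inhibitor. Compounds 1 and 2 differ in more than one place and could not show the effect of any single position, whereas this pair isolates one atom and gives a step beyond the scatter. No measurement at hand explains the size or direction of this step.

Still open, from the compounds shown here alone, is how other groups at this position, such as fluoro, methyl, methoxy or an amine, would compare with hydrogen and chloro. Going by these compounds, it is also open whether the same swap would give a similar step on the urea-linked ring of compound 1.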